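Acylurea saccharin derivatives: stability beyond the assay limit

The compounds below may be only part of what the source reports. "The series", "measured", "known", "first", "only" and "open" are said of these compounds alone.

Compound 1, `O=C(NCc1ccccc1Br)N1C(=O)c2ccccc2S1(=O)=O`, in a physicochemical assay for pharmacokinetics (on this read-out lower numbers stand for a shorter-lived compound and higher numbers for a longer-lived compound), gives > 166 h, a limit of the assay.
Compound 2, `O=C(NCc1cccc(Br)c1)N1C(=O)c2ccccc2S1(=O)=O`, in this assay gives > 166 h, a limit of the assay.
Compound 3, `O=C(NCc1ccccc1)N1C(=O)c2ccccc2S1(=O)=O`, in this assay gives > 166 h, a limit of the assay.

All three measured compounds sit at the same limit, (the limit of > 166 h in this assay, at which 3 of the 3 values shown sit). The steps among them are therefore unreadable: a step that the two limits leave unreadable from compound 1 to compound 2, a step that the two limits leave unreadable from compound 1 to compound 3 and a step that the two limits leave unreadable from compound 2 to compound 3. Compound 3 thus stands at the upper limit, with no number to separate it from the others.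

Compound 4, `CC(NC(=O)N1C(=O)c2ccccc2S1(=O)=O)c1ccccc1`, differs from compound 3 by methyl in place of hydrogen on a saturated chain carbon bound to an amide-type nitrogen and an aromatic carbon. Within the data shown here, none of the measured steps bears readably on this change, since every step is hidden by the limit. Compound 4 is expected to remain long-lived in this assay, an estimate of 166 h, ranging from 100 h to 400 h, the expected step of a number no higher from compound 3 to compound 4 (the limit leaves the size open) being no more than scatter.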

Compound 4, half-life: > 166 h
Compound 4: a limit, no number; the forecaster's own chance of this, stated with the estimate: 80%; the middle value sits exactly at the limit.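

Among these compounds, compound 4, like compound 3, gives a limit and not a number, so no step between them can be read: the limit of > 166 h in this assay, at which 4 of the 4 values shown sit. The compounds shown leave open how long any of them actually lasts in this assay, and whether methyl or bromo changes that at all.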